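Dropping the ring-nitrogen substituent in the pyrazoline amides

The source may report more compounds than this note shows. Statements on the series, on what has been measured and on what is new or still open speak of the compounds shown alone.

Two compounds of this series have been run in a functional assay on the whole organism (plasma, strain albino) for inhibition, with Rattus norvegicus as the target, with stated times of 1 h and 4 h, at a dose of 50 mg/kg by the oral route; on this read-out lower numbers stand for a weaker effect and higher numbers for a stronger effect at the one dose given. Compound 1 `COc1ccc(C2CC(c3ccc(NC(=O)c4cc(Cl)ccc4OC)cc3)=NN2C)cc1` gives 81.8% in this assay. Compound 2 `COc1ccc(C2CC(c3ccc(NC(=O)c4cc(Cl)ccc4OC)cc3)=NN2c2ccccc2)cc1` gives 90.2% in this assay; the two numbers lie close together, since a number 8.4 percentage points higher from compound 1 to compound 2 (within the scatter).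

Compound 3 `COc1ccc(C2CC(c3ccc(NC(=O)c4cc(Cl)ccc4OC)cc3)=NN2)cc1` is the next member and has not been measured in this assay. It differs from compound 2 by hydrogen in place of phenyl on an amine nitrogen in a ring.

For the measured compounds named here, the only step that bears on this change is the one from compound 1 to compound 2, where phenyl replaced methyl at the same ring nitrogen, and it stayed within the scatter. Removing the phenyl again, down to hydrogen, is therefore expected to give no step beyond the scatter in this assay, with the estimated shift being a number 10.2 percentage points lower from compound 2 to compound 3 (beyond the scatter).

On that basis compound 3 is estimated at 80% in this assay, within a range of 60% to 93%.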

Compound 3, a percentage reported as inhibition, in the whole organism at one dose (the size of the read-out at that dose, not a potency): 83%
For compound 3 the middle estimate is 3 percentage points below the measured one; the measured number falls inside the stated range.
By their numbers in this assay, from the lowest: compounds 1, 3 and 2 (each within the scatter of the next).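

In this assay hydrogen in place of phenyl gives a number 7.2 percentage points lower from compound 2 to compound 3 (within the scatter) and hydrogen in place of methyl gives a number 1.2 percentage points higher from compound 1 to compound 3 (within the scatter) at this ring nitrogen, so the unsubstituted compound 3 cannot be told apart from either substituted compound. The earlier step compared only two substituents; this one shows that, among the three compounds, the read-out at this one dose does not depend on a carbon group being present on the nitrogen. Nothing at hand bears on the reason for this flat result.

From the compounds shown here alone, whether an acetyl group, a longer chain such as butyl or a chain ending in a carboxylic acid at this nitrogen would move the number beyond the scatter remains open. Also open, going by these compounds, is whether compounds 1, 2 and 3 would stay this close at a lower dose.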